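Replacing Methyl with Chloro in Compound 1

The compounds below may be only part of what the source reports. "The series", "measured", "known", "first", "only" and "open" are said of these compounds alone.

Compound 1 `Cc1ccc(C(=O)/C=C/c2cc(Br)cc(Br)c2Oc2c([N+](=O)[O-])cc(C(F)(F)F)cc2[N+](=O)[O-])cc1` gives 1.44 ug/mL
Compound 2 `Cc1ccc(C(=O)/C=C/c2cccc(Br)c2Oc2c([N+](=O)[O-])cc(C(F)(F)F)cc2[N+](=O)[O-])cc1` gives 0.55 ug/mL
Compound 3 `COc1ccc(C(=O)/C=C/c2cc(Cl)cc(Cl)c2Oc2c([N+](=O)[O-])cc(C(F)(F)F)cc2[N+](=O)[O-])cc1` gives 2.69 ug/mL

These three compounds were tested in a functional assay on MCF7 cells (Homo sapiens) for antiproliferative activity, read by MTT assay, with a stated time of 48 h (on this read-out higher numbers stand for weaker inhibition and lower numbers for stronger inhibition), and leave compound 1 in a clear position on one side only. Its value is not separated by more than the scatter from that of compound 3, whereas compound 2 stands apart, as a 2.6-fold lower number from compound 1 to compound 2 (0.42 log units; beyond the scatter) shows.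

Compound 4 `O=C(/C=C/c1cc(Br)cc(Br)c1Oc1c([N+](=O)[O-])cc(C(F)(F)F)cc1[N+](=O)[O-])c1ccc(Cl)cc1` has not yet been measured. It departs from compound 1 by one change, chloro in place of methyl on an aromatic carbon, which turns 4-methylphenyl into 4-chlorophenyl. Within the data shown here, the single measured step is hydrogen in place of bromo on an aromatic carbon. It is modest and leaves the 4-methylphenyl group untouched, so it bears on this change only indirectly, as a guide to how far one small substitution can move the number. Compound 3 differs from compound 1 in more than one place and isolates nothing. No measurement tests methyl against chloro here, so the estimate stays anchored on compound 1 (1.44 ug/mL) and no step beyond the scatter is expected in this assay in either direction. The expected step is small (a 1.0-fold lower number from compound 1 to compound 4 (0.01 log units; within the scatter)). Compound 4 is expected near 1.4 ug/mL (estimated range 0.6 ug/mL to 3.3 ug/mL).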

Compound 4, half-maximal inhibitory concentration: 6.76 ug/mL
Compound 4: middle estimate off by 4.8-fold (0.68 log units), on the low side; the measured number lies above the stated range.
By their numbers in this assay, from the lowest: compound 2; then compounds 1 and 3 (each within the scatter of the next); then compound 4.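

In this assay, among these compounds, the 4-methylphenyl group of compound 1 proves to be a position that responds to change: turning it into 4-chlorophenyl gives a 4.7-fold higher number from compound 1 to compound 4 (0.67 log units; beyond the scatter), the first measured step at this end of the molecule. The swap exchanges one heavy atom for one other, on an aromatic carbon para to a large group, and involves no ring, hydrogen-bond donor, hydrogen-bond acceptor or net charge, yet it moves the number beyond the scatter towards weaker inhibition, whereas the earlier step elsewhere on the molecule, a 2.6-fold lower number from compound 1 to compound 2 (0.42 log units; beyond the scatter), ran towards stronger inhibition. No measurement available here accounts for the difference between methyl and chloro at this position.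

From the compounds shown here alone, whether the same exchange would have a similar effect on the core of compound 2, which has hydrogen in place of one bromo, remains open. It is also unknown how this position would respond to other groups, such as fluoro, an unsubstituted phenyl, an amine or a carboxylic acid, so these two compounds define no trend across substituents.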